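Oxazole-fused heteroaryl ketones as fatty-acid amide hydrolase inhibitors

The source may hold more compounds than are shown below. What is called first, only, known or untested is meant among the compounds shown, and "the series" means these compounds.

Compound 1, `O=C(CCCCCCc1ccccc1)c1nnn[nH]1`: in this assay, > 1000 nM (a limit)
Compound 2, `CCCCCCCC/C=C\CCCCCCC(=O)c1nc2cnccc2o1`: 7.2 nM
Compound 3, `O=C(CCCCSCc1ccccc1)c1ncc(-c2ccccn2)o1`: 25 nM

All three compounds were examined in an assay on isolated protein for inhibition of Fatty-acid amide hydrolase 1 (Homo sapiens); on this read-out higher numbers stand for weaker inhibition and lower numbers for stronger inhibition. Compound 1, with its acidic five-membered ring, reaches only the limit of the assay, > 1000 nM, so no number is known for it; (the limit of > 1000 nM in this assay, at which 1 of the 3 values shown sits). Of the two compounds with a measured number, compound 2 holds the lower one, 7.2 nM, and compound 3 sits higher at 25 nM, a gap that lies beyond the usual scatter of repeated measurements. Compound 2 therefore stands as the strongest inhibitor among the measured numbers.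

Compound 4, `CCCCCCCC/C=C\CCCCCCC(=O)c1nc2ncccc2o1`, has not yet been measured. It keeps the whole long unsaturated chain and the carbonyl of compound 2 and differs only in the bicyclic group on the carbonyl carbon: a group of 9 heavy atoms (6 carbon, 2 nitrogen, 1 oxygen; one five-membered aromatic ring with 2 hetero atoms, one six-membered aromatic ring with 1 hetero atom) in place of a group of 9 heavy atoms (6 carbon, 2 nitrogen, 1 oxygen; one five-membered aromatic ring with 2 hetero atoms, one six-membered aromatic ring with 1 hetero atom), on a carbonyl carbon. The two compounds have the same atoms, joined differently, so the change is a rearrangement of a group of 9 heavy atoms (6 carbon, 2 nitrogen, 1 oxygen; one five-membered aromatic ring with 2 hetero atoms, one six-membered aromatic ring with 1 hetero atom) rather than any change in size or composition.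

Within the data shown here, no measured pair shows what such a rearrangement does in this assay. A rearrangement of this kind is expected to move the number little, if at all beyond the scatter, in either direction. For compound 4 the estimated value is 10 nM, with a range of 3 nM to 35 nM, which corresponds to an expected step of a 1.4-fold higher number from compound 2 to compound 4 (0.14 log units; within the scatter).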

Compound 4, inhibition constant: 2.3 nM
Beside the measured number, compound 4's estimate is 4.3-fold (0.64 log units) above it, outside the stated range (below it).
By their numbers in this assay, from the lowest: compound 4; then compound 2; then compound 3. At a limit, above all of these: compound 1.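

The step of a 3.1-fold lower number from compound 2 to compound 4 (0.50 log units; beyond the scatter) in this assay shows that the group on the carbonyl carbon responds to how its atoms are joined, not only to which atoms it holds. The group that leaves and the group that enters have the same 9 heavy atoms, the same two aromatic rings, the same 0 hydrogen-bond donors and 3 hydrogen-bond acceptors, and no net charge, while the long unsaturated chain and the carbonyl stay as they were. Among these compounds, the earlier compounds offered no pair differing in one place, so this is the first direct reading at this position, though nothing given here explains why the rearrangement moves the number.

Still open, going by these compounds, is whether another arrangement of the same atoms, or a methyl group or carboxylic acid added to the six-membered aromatic ring, would move the number further in either direction. On these data alone, it is also open whether a step of this size would carry over if a shorter saturated chain took the place of the long unsaturated chain.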